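The source may hold more compounds than are shown below. What is called first, only, known or untested is meant among the compounds shown, and "the series" means these compounds.

Measured compounds:
Compound 1 `C=C/C(C)=C/CC/C(C)=C/c1cc(C(=O)OC)co1` gives 25800 nM.
Compound 2 `C=C/C(C)=C\CC/C(C)=C/c1cc(C(=O)Nc2ccc(C)cc2)co1` gives 60400 nM.
Compound 3 `C=C/C(C)=C\CC/C(C)=C/c1cc(C(=O)N2CCN(C(c3ccccc3)c3ccccc3)CC2)co1` gives 17800 nM.

All three were read in a functional assay on THP-1 cells (Homo sapiens) for cytotoxicity, read by MTT assay, with a stated time of 48 h; on this read-out lower numbers stand for stronger inhibition and higher numbers for weaker inhibition. Among the three numbers, compound 2 stands highest: its nearest neighbour is compound 1, whose value lies beyond the usual scatter below it, and compound 3 lies further still below it, also beyond the scatter. Within this small set, then, compound 2 is the weakest inhibitor of the three.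

The step under consideration goes from compound 2 to the unmeasured compound 4 `C=C/C(C)=C\CC/C(C)=C/c1cc(C(=O)OC)co1`. The change is methoxy in place of (4-methylphenyl)amino on a carbonyl carbon. For the measured compounds named here, no pair of measured compounds differs in exactly one place, so the size of this step has to be judged from what the three values show. Compound 1 also carries a methoxy on the carbonyl carbon and gives 25800 nM, a value clearly below that of compound 2, and this is the closest guide available.

On that basis the step is expected to be a decrease beyond the scatter, a 2.3-fold lower number from compound 2 to compound 4 (0.37 log units; beyond the scatter), toward stronger inhibition in this assay. Compound 4 is therefore estimated at 26000 nM, with a likely range from 12000 nM to 55000 nM.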

Compound 4, half-maximal inhibitory concentration: 51400 nM
Beside the measured number, compound 4's estimate is 2.0-fold (0.30 log units) below it, and the stated range covers the measured number.
By their numbers in this assay, from the lowest: compounds 3, 1, 4 and 2 (each within the scatter of the next, the first and the last beyond it).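

The earlier compounds shown here offered no step in a single place; now there are two, and neither leaves the usual scatter in this assay. With the double bonds drawn alike, methoxy in place of (4-methylphenyl)amino on a carbonyl carbon exchanges a larger group holding an aromatic ring and a hydrogen-bond donor for a small one with no ring, yet the read-out does not separate the two compounds (a 1.2-fold lower number from compound 2 to compound 4 (0.07 log units; within the scatter)). The second step also stays within the scatter (a 2.0-fold higher number from compound 1 to compound 4 (0.30 log units; within the scatter)), and it isolates the drawn geometry of one double bond, a comparison that rests on the following: the fact that compounds 1 and 4 differ only in the configuration as drawn

What the compounds leave open is whether any group on this carbonyl carbon can move the number beyond the scatter, for instance a carboxylic acid, a simple unsubstituted amine or a longer alkoxy chain. The value of compound 3 also remains unplaced, as it has no partner that differs from it in one place, so the contribution of its larger group to 17800 nM cannot be read.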